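A few compounds are considered here, and "the series" means these few. Any claim that something is new, unique, unknown or untested is made for them only; others in the source may bear on it.

Compound 1 `COc1ccc(S(=O)(=O)N2CCc3cccc(-c4ccc(C#N)cc4)c32)cc1` carries a 4-cyanophenyl group on its core. In a functional assay on KB-VIN10 cells (Homo sapiens) for inhibition, with a stated time of 72 h (a lower number here means a stronger inhibitor, a higher number a weaker inhibitor), compound 1 gives 29.2 nM, the lowest of the three numbers measured. Compound 2 `COc1ccc(S(=O)(=O)N2CCc3cccc(-c4c(F)c(F)c(F)c(F)c4F)c32)cc1` gives 4630 nM and compound 3 `COc1ccc(S(=O)(=O)N2CCc3cccc(-c4cc(OC)c(OC)c(OC)c4)c32)cc1` gives 4670 nM, both far beyond the scatter from compound 1. Compound 4 `COc1ccc(S(=O)(=O)N2CCc3cccc(-c4cccs4)c32)cc1` has not been measured; it differs from compound 1 in one place: thiophen-2-yl in place of 4-cyanophenyl on an aromatic carbon. Among the compounds with values here, no measured pair differs in one place, so the size of this step is unknown. Because compound 2 gives 4630 nM and compound 3 gives 4670 nM, both well behind compound 1, a loss beyond the scatter is expected from compound 1 to compound 4, an 8.6-fold higher number from compound 1 to compound 4 (0.93 log units; beyond the scatter). Compound 4 is estimated at 250 nM, within 40 nM to 1500 nM.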

Compound 4, half-maximal inhibitory concentration: 251 nM
Estimate against measurement, compound 4: 1.0-fold (0.00 log units) below; the range from low to high includes it.
By their numbers in this assay, from the lowest: compound 1; then compound 4; then compounds 2 and 3 (each within the scatter of the next).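

In this assay, within the data shown here, this is the first single change read at this aromatic carbon: thiophen-2-yl in place of 4-cyanophenyl gives an 8.6-fold higher number from compound 1 to compound 4 (0.93 log units; beyond the scatter), a loss beyond the scatter. The position therefore responds to the group it carries, yet it can hold a five-membered aromatic ring with a sulfur atom, with compound 4 giving 251 nM. Nothing measured here explains the size of this step. The compounds shown leave open how much of the step belongs to the nitrile and how much to the ring itself, which an unsubstituted phenyl or a 4-aminophenyl group at this position would help to separate.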